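Lengthening the amine chains of compound 3

The compounds below may be only part of what the source reports. "The series", "measured", "known", "first", "only" and "open" are said of these compounds alone.

Of the compounds shown here, three have been tested in a functional assay for antagonist activity, with Cavia porcellus as the target; on this read-out higher numbers stand for weaker inhibition and lower numbers for stronger inhibition. Compound 1 `CCN(CC)CC#CCCC1SCCCS1` gives only a limit, > 10000000 nM, and not a true number. Compound 2 `CCN(CC)CC#CCCC1(C(O)(c2ccccc2)C2CCCCC2)SCCCS1` gives 1140 nM. Compound 3 `CCN(CC)CC#CCC1(c2ccccc2)SCCCS1` gives 4270 nM, the higher of the two true numbers, so it inhibits less strongly than compound 2. Compound 4 `CCCN(CC#CCC1(c2ccccc2)SCCCS1)CCC` keeps the rest of compound 3 but has dipropylamino in place of diethylamino on a saturated chain carbon bound to a triple-bonded carbon. Going by the values given here, no measured pair shows this change alone, so any forecast is loose. The expected step is a 1.4-fold higher number from compound 3 to compound 4 (0.15 log units; within the scatter), a slightly higher number that would stay within the usual scatter. For compound 4 the estimated value is 6000 nM, with an expected range from 1500 nM to 24000 nM.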

Compound 4, antagonist equilibrium constant: 1010 nM
For compound 4 the middle estimate is 5.9-fold (0.77 log units) above the measured one; the whole stated range lies above it.
By their numbers in this assay, from the lowest: compounds 4 and 2 (each within the scatter of the next); then compound 3. At a limit, above all of these: compound 1.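

This is the first measured change at the amine end of these compounds, and it shows that this end affects activity. In this assay there is a 4.2-fold lower number from compound 3 to compound 4 (0.63 log units; beyond the scatter) when dipropylamino replaces diethylamino on a saturated chain carbon bound to a triple-bonded carbon, so the longer chains here go with stronger inhibition. Nothing measured here explains this step.

A single step cannot show whether dibutylamino would go further or whether a cyclic amine such as piperidine would serve as well. As far as these compounds go, whether the same change would act alike on the core of compound 2 also remains open.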